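Furan to Pyrrole on the Carbon Bearing the Imine

A few compounds are considered here, and "the series" means these few. Any claim that something is new, unique, unknown or untested is made for them only; others in the source may bear on it.

Of the compounds shown here, three built on one shared core have been measured, each carrying a different group on the carbon with a double bond to nitrogen. In a functional assay on UACC-62 cells (Homo sapiens) for inhibition, read by sulforhodamine B assay, with a stated time of 48 h (on this read-out lower numbers stand for stronger inhibition of growth and higher numbers for weaker inhibition of growth), compound 1 `CC1=CC[C@H](C(C)(C)NC(=S)N/N=C/c2ccc(F)cc2)CC1` gives only a limit of the assay, > 100000 nM, not a number. Compound 2 `CC1=CC[C@H](C(C)(C)NC(=S)N/N=C/c2cccc(Cl)c2)CC1` gives 39800 nM in this assay. Compound 3 `CC1=CC[C@H](C(C)(C)NC(=S)N/N=C/c2ccco2)CC1` gives 14100 nM in this assay, the lowest of the two numbers shown; its nearest neighbour is compound 2, with the step of a 2.8-fold lower number from compound 2 to compound 3 (0.45 log units; beyond the scatter) lying beyond the scatter, and the step of an at least 7.0-fold lower number from compound 1 to compound 3 (0.85 log units; beyond the scatter) is larger still.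

Compound 4 `CC1=CC[C@H](C(C)(C)NC(=S)N/N=C/c2ccc[nH]2)CC1` differs from compound 3 in a single place: 1H-pyrrol-2-yl in place of furan-2-yl on a carbon with a double bond to nitrogen. The measured steps of an at least 2.5-fold lower number from compound 1 to compound 2 (0.40 log units; beyond the scatter) and a 2.8-fold lower number from compound 2 to compound 3 (0.45 log units; beyond the scatter) show that exchanging the group at this position moves the read-out by modest amounts, but none of them swaps one five-membered ring for another, so their bearing is indirect. A step of no more than modest size is therefore expected, in either direction, and most likely none beyond the scatter, as a 1.2-fold lower number from compound 3 to compound 4 (0.07 log units; within the scatter). Compound 4 is estimated at 12000 nM, between 4000 nM and 40000 nM.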

Compound 4, concentration for total growth inhibition: 49900 nM
Compound 4: the middle estimate sits 4.2-fold (0.62 log units) below what was measured; the whole stated range lies below it.
By their numbers in this assay, from the lowest: compound 3; then compounds 2 and 4 (each within the scatter of the next). At a limit, above all of these: compound 1.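

Swapping one five-membered aromatic ring for another at this place, on a carbon with a double bond to nitrogen, gives the first direct test of that kind, and in this assay the result is a 3.5-fold higher number from compound 3 to compound 4 (0.55 log units; beyond the scatter) even though both rings hold the same number of heavy atoms. The step of a 1.3-fold higher number from compound 2 to compound 4 (0.10 log units; within the scatter) stays inside the scatter, so a five-membered aromatic ring does not by itself bring the lower number that furan-2-yl gives. Compound 1 remains a limit of the assay and not a number, so an at least 2.0-fold lower number from compound 1 to compound 4 (0.30 log units; that floor lies within the scatter) gives only a floor: the limit of > 100000 nM in this assay, at which 1 of the 4 values shown sits.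

The compounds shown do not tell whether thiophen-2-yl, with sulfur in the ring, would fall nearer compound 3 or compound 4. They also leave open what a methyl group on the pyrrole nitrogen would do to the read-out.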